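Bromo for fluoro on two related cores

The source may report more compounds than this note shows. Statements on the series, on what has been measured and on what is new or still open speak of the compounds shown alone.

Of the compounds shown here, three have been measured in a functional assay on MCF7 cells (Homo sapiens) for inhibition, read by MTT assay, with a stated time of 48 h; on this read-out higher numbers stand for weaker inhibition and lower numbers for stronger inhibition. Compound 1 `O=C(C=CNc1cc(-c2ccccc2)nn1-c1ccccc1)c1ccc(Br)cc1` and compound 3 `O=C(C=CNc1cc(-c2ccccc2)nn1-c1ccccc1)c1ccc(F)cc1` share one core and differ only in that compound 1 carries bromo in place of fluoro on an aromatic carbon. In this assay compound 3 gives 9180 nM, while compound 1 gives 21700 nM; the step is a 2.4-fold higher number from compound 3 to compound 1 (0.37 log units; beyond the scatter). Compound 2 `Fc1ccc(-c2ccnc3c2c(-c2ccccc2)nn3-c2ccccc2)cc1` is built on a second core; the difference between the two cores is not broken down here. In this assay compound 2 gives 1570 nM, the lowest number of the three.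

Compound 4 `Brc1ccc(-c2ccnc3c2c(-c2ccccc2)nn3-c2ccccc2)cc1` has not yet been measured. It stands to compound 2 as compound 1 stands to compound 3: bromo in place of fluoro on an aromatic carbon, the same change at the same kind of position. Because the earlier exchange gave a 2.4-fold higher number from compound 3 to compound 1 (0.37 log units; beyond the scatter), a step of similar size is expected from compound 2 to compound 4, namely a 2.3-fold higher number from compound 2 to compound 4 (0.36 log units; beyond the scatter), with the caveat that the core is different. Compound 4 is therefore estimated at 3600 nM, between 1300 nM and 10000 nM.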

Compound 4, half-maximal inhibitory concentration: 13300 nM
Estimate against measurement, compound 4: 3.7-fold (0.57 log units) below; measured number above the stated range.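

In this assay, putting bromo in place of fluoro on the second core gives an 8.5-fold higher number from compound 2 to compound 4 (0.93 log units; beyond the scatter), so the number goes up here just as it did on the first core. The direction of the change therefore carries over in these two pairs, with bromo giving weaker inhibition than fluoro each time, but its size does not carry over: the same change on two cores in this assay, a 2.4-fold higher number (0.37 log units; beyond the scatter) from compound 3 to compound 1 and an 8.5-fold higher number (0.93 log units; beyond the scatter) from compound 2 to compound 4, 3.6-fold (0.55 log units) apart, beyond the scatter of two such steps. This shows that the step measured on one core was a poor guide to how large the step would be on the other; it does not show why the two cores differ, and two pairs give no rule for any third core.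

The compounds shown leave open whether other groups in the same place, such as chloro, methoxy or an amine, would keep the same order on both cores. They also leave open which parts of the two cores are responsible for the different step sizes, since the cores differ in more than one place.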